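Piperidine for methylpiperazine in two matched pairs

The source may report more compounds than this note shows. Statements on the series, on what has been measured and on what is new or still open speak of the compounds shown alone.

Compound 1 `CN1CCN(c2ccc(Nc3ncc4c(n3)N(C3CCCC3)CC(=O)N4C)cc2)CC1` and compound 2 `CN1C(=O)CN(C2CCCC2)c2nc(Nc3ccc(N4CCCCC4)cc3)ncc21` share one core and differ in a single place. In an ADME assay on HEK293 cells (Homo sapiens) for inhibition, read by MTT assay, with a stated time of 48 h (a higher number here means a weaker inhibitor, a lower number a stronger inhibitor), compound 1 gives 12400 nM and compound 2 gives 25300 nM; the step of a 2.0-fold higher number from compound 1 to compound 2 (0.31 log units; beyond the scatter) goes with piperidin-1-yl in place of 4-methylpiperazin-1-yl on an aromatic carbon. Compound 3 `CN1CCN(c2ccc(Nc3ncc4c(n3)N(C3CCCC3)CC(=O)N4C)nc2)CC1` was run in this assay and gives "not determined" (no result reported), that is, no result was reported for it. Compound 4 `CN1C(=O)CN(C2CCCC2)c2nc(Nc3ccc(N4CCCCC4)cn3)ncc21` has not been measured in this assay. The change from compound 3 to compound 4 is piperidin-1-yl in place of 4-methylpiperazin-1-yl on an aromatic carbon, the same kind of change as from compound 1 to compound 2, although the surroundings differ: in the first pair the group sits on an aromatic carbon of a six-membered aromatic ring of carbon only, para to a large group, in the second pair on an aromatic carbon of a six-membered aromatic ring with 1 nitrogen, two atoms from the ring nitrogen, para to a large group. The difference between the two cores is not broken down here. Among the measured compounds shown here, because a 2.0-fold higher number from compound 1 to compound 2 (0.31 log units; beyond the scatter) is the only step of this kind and is modest, a modest step from compound 3 to compound 4 in this assay is expected. Compound 3 gives no number to anchor it, so the estimate leans on compound 2 and its value 25300 nM. Compound 4 is expected to give about 25000 nM in this assay, between 8000 nM and 80000 nM.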

Compound 4, half-maximal inhibitory concentration: > 30000 nM
Compound 4: only a limit was reported; the forecaster's own chance of this, stated with the estimate: 25%; middle value at least 1.2-fold (0.07 log units) from the limit.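

Compound 3 gives no number and compound 4 carries only a limit of the assay, so no new step can be read between compound 3 and compound 4: the limit of > 30000 nM in this assay, at which 1 of the 4 values shown sits.

The compounds shown leave open whether piperidin-1-yl in place of 4-methylpiperazin-1-yl on a six-membered aromatic ring with 1 nitrogen matches the step of a 2.0-fold higher number from compound 1 to compound 2 (0.31 log units; beyond the scatter).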